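From 3-fluorophenyl to 4-bromophenyl on the amide nitrogen

The source may report more compounds than this note shows. Statements on the series, on what has been measured and on what is new or still open speak of the compounds shown alone.

- compound 1 (`COc1cc(/C=C/C(=O)NO)ccc1OCC(=O)Nc1ccccc1F`) gives 11100 nM
- compound 2 (`COc1cc(/C=C/C(=O)NO)ccc1OCC(=O)Nc1cccc(F)c1`) gives 34500 nM

In a functional assay on HeLa cells (Homo sapiens) for inhibition, read by MTT assay, with a stated time of 48 h (a higher number here means a weaker inhibitor, a lower number a stronger inhibitor), compound 2 at 34500 nM has the higher number of the two measured compounds. Compound 3 (`COc1cc(/C=C/C(=O)NO)ccc1OCC(=O)Nc1ccc(Br)cc1`) differs from it by one change (4-bromophenyl in place of 3-fluorophenyl on an amide-type nitrogen), with 4-bromophenyl in place of 3-fluorophenyl on an amide-type nitrogen. Going by the values given here, one measured step bears on this (a 3.1-fold higher number from compound 1 to compound 2 (0.49 log units; beyond the scatter)), modest and made at the same place. For compound 3 a step no larger, probably within the scatter and leaning towards a lower number, is expected in this assay (a 1.6-fold lower number from compound 2 to compound 3 (0.20 log units; within the scatter)). Compound 3 is estimated at 22000 nM (range 8000 nM to 60000 nM).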

Compound 3, half-maximal inhibitory concentration: > 100000 nM
Compound 3: no number, only a limit (the forecaster's own chance of this, stated with the estimate: 5%); middle value at least 4.5-fold (0.65 log units) away from the limit.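

Compound 3 stands at a limit of the assay, not at a number: the limit of > 100000 nM in this assay, at which 1 of the 3 values shown sits. In this assay, 4-bromophenyl on the amide-type nitrogen gives an at least 2.8-fold higher number from compound 2 to compound 3 (0.46 log units; beyond the scatter), and measured against 2-fluorophenyl it gives an at least 9.0-fold higher number from compound 1 to compound 3 (0.95 log units; beyond the scatter). The two fluorophenyl compounds showed only a modest step, whereas this change reaches the limit of the assay, so the group at this position can move the result further than they indicated.

Going by these compounds, whether the bromine or its place carries this step stays open. So does what a plain phenyl, 4-fluorophenyl or 4-chlorophenyl would give on the same nitrogen.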